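Permeability of a methylphenyl analogue in the oxazole series

A few compounds are considered here, and "the series" means these few. Any claim that something is new, unique, unknown or untested is made for them only; others in the source may bear on it.

Compound 1 `Cc1ccccc1-c1nc(CN2CCC(C(=O)NCCCN3CCC(C(C)C)CC3)CC2)c(C)o1`: 396 10^-6 cm/s
Compound 2 `Cc1oc(-c2ccc(Cl)cc2)nc1CN1CCC(C(=O)NCCCN2C[C@H](C)C[C@H](C)C2)CC1`: > 635 10^-6 cm/s
Compound 3 `Cc1ccccc1-c1nc(CN2CCC(C(=O)NCCCCN3C[C@H](C)C[C@H](C)C3)CC2)c(C)o1`: 288 10^-6 cm/s

Three compounds of this series have been characterised in a physicochemical assay for permeability, using PAMPA; on this read-out higher numbers stand for higher permeability and lower numbers for lower permeability. Compound 1 gives 396 10^-6 cm/s in this assay, and compound 3 gives 288 10^-6 cm/s. For compound 2 only a limit is known, > 635 10^-6 cm/s, which marks the limit of > 635 10^-6 cm/s in this assay, at which 1 of the 3 values shown sits, and is not a number. Going by the values given here, the one step between compounds that differ in a single place, a 1.4-fold lower number from compound 1 to compound 3 (0.14 log units; within the scatter), concerns the saturated chain end of the molecule and lies within the scatter.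

Compound 4 `Cc1cccc(-c2nc(CN3CCC(C(=O)NCCCN4C[C@H](C)C[C@H](C)C4)CC3)c(C)o2)c1` differs from compound 2 by 3-methylphenyl in place of 4-chlorophenyl on an aromatic carbon. No measured step touches this aromatic position, so nothing among the shown steps bears directly on the change; what is at hand is that compound 1 and compound 3, which both carry a methyl-substituted phenyl on the shared core, give numbers in this assay rather than limits, and that compound 2 stands at the limit. The account therefore expects the step of an at least 1.5-fold lower number from compound 2 to compound 4 (0.17 log units; that floor lies within the scatter) to bring compound 4 down from the limit into the measurable range. Compound 4 is estimated at 420 10^-6 cm/s in this assay, with a range from 220 10^-6 cm/s to 700 10^-6 cm/s.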

Compound 4, apparent permeability: 279 10^-6 cm/s
Estimate against measurement, compound 4: 1.5-fold (0.18 log units) above, within the range that was stated.
By their numbers in this assay, from the lowest: compounds 4, 3 and 1 (each within the scatter of the next). At a limit, above all of these: compound 2.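

This step is the first among those shown at this aromatic carbon of the five-membered aromatic ring with 1 nitrogen and 1 oxygen, and in this assay the change from 4-chlorophenyl to 3-methylphenyl goes beyond the scatter: it gives an at least 2.2-fold lower number from compound 2 to compound 4 (0.35 log units; beyond the scatter). The two groups have the same count of heavy atoms and each is one six-membered aromatic ring of carbon only, so the step comes with a swap of chlorine for a methyl group and a shift in where the substituent stands on that ring, and this single pair cannot separate the two. Compound 2 stands at a limit and not at a number, so the step gives only a floor because of where that compound sits: the limit of > 635 10^-6 cm/s in this assay, at which 1 of the 4 values shown sits.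

The compounds shown leave open whether 3-chlorophenyl or 4-methylphenyl at this carbon would read with compound 2 or with compound 4, which would tell the substituent apart from its place on the ring. They also leave open how an unsubstituted phenyl or a methoxyphenyl would read here in this assay.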